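Series notes: ethyl in place of phenyl on ring nitrogen

This account rests on a few compounds, and the source may have more. Where it says the series, first, only, none or still open, it means among the compounds named here.

Measured so far in a functional assay on the whole organism (strain albino) for inhibition, with Rattus norvegicus as the target, read by paw edema, with a stated time of 1 h, at a dose of 0.28 mmol/kg by the oral route; on this read-out lower numbers stand for less inhibition and higher numbers for more inhibition at the one dose given (going by the name of the read-out):
Compound 1 `COc1ccc(-c2nnc(SCC(=O)c3ccccc3)n2-c2ccccc2)cc1OC` gives 56%.
Compound 2 `O=C(CSc1nnc(-c2ccccc2)n1-c1ccccc1)c1ccccc1` gives 53%.

Compound 1 stands highest of the two numbers; its nearest neighbour is compound 2, and the step of a number 3 percentage points lower from compound 1 to compound 2 (within the scatter) lies within the scatter, so the two cannot be ordered.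

Compound 3 `CCn1c(SCC(=O)c2ccccc2)nnc1-c1ccc(OC)c(OC)c1` has not been measured. It differs from compound 1 by ethyl in place of phenyl on an aromatic nitrogen. Going by the values given here, no measured step touches this position: the one known step, from compound 1 to compound 2, concerns a different group on a different part of the shared core and was itself within the scatter. The change to compound 3 therefore has no direct precedent in the series, and in this assay the expected step is none beyond the scatter, with the range kept wide for that reason.

The estimate for compound 3 in this assay is 50%, between 32% and 66%, meaning an expected step of a number 6 percentage points lower from compound 1 to compound 3 (within the scatter).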

Compound 3, a percentage reported as inhibition, in the whole organism at one dose (the size of the read-out at that dose, not a potency): 42%
Beside the measured number, compound 3's estimate is 8 percentage points above it; the measured number falls inside the stated range.
By their numbers in this assay, from the lowest: compound 3; then compounds 2 and 1 (each within the scatter of the next).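

In this assay, going by these compounds alone, the aromatic nitrogen is the first position where a single change leaves the scatter: ethyl in place of phenyl gives a number 14 percentage points lower from compound 1 to compound 3 (beyond the scatter), whereas the one earlier step, a number 3 percentage points lower from compound 1 to compound 2 (within the scatter), stayed within it. Within the data shown here, the change takes away a six-membered aromatic ring of carbon only and puts a group of 2 heavy atoms with no ring in its place, so the phenyl on this nitrogen counts for more in this read-out than the earlier compounds could show. Nothing measured here explains the drop.

Still open, from the compounds shown here alone, is whether a cyclohexyl or benzyl group on this nitrogen would keep the number near that of compound 1, which would help separate the aromatic ring from the size of the group. A longer chain such as butyl would show whether size alone matters at this position.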